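A few compounds are considered here, and "the series" means these few. Any claim that something is new, unique, unknown or untested is made for them only; others in the source may bear on it.

Working notes on the series. Compound 1 `CCC(C)n1ncn(-c2ccc(N3CCN(c4ccc(OC[C@@H]5CO[C@@](CBr)(c6ccc(Cl)cc6Cl)O5)cc4)CC3)cc2)c1=O` carries bromo on a saturated chain carbon of the shared core, compound 2 `CCC(C)n1ncn(-c2ccc(N3CCN(c4ccc(OC[C@@H]5CO[C@@](CN6CCN(C)CC6)(c6ccc(Cl)cc6Cl)O5)cc4)CC3)cc2)c1=O` carries 4-methylpiperazin-1-yl there, and compound 3 `CCC(C)n1ncn(-c2ccc(N3CCN(c4ccc(OC[C@@H]5CO[C@@](Cn6cnc(C)n6)(c6ccc(Cl)cc6Cl)O5)cc4)CC3)cc2)c1=O` carries 3-methyl-1H-1,2,4-triazol-1-yl. In a functional assay on HUVEC cells (Homo sapiens), read by scintillation counting and thymidine incorporation, with a stated time of 24 h (a lower number here means a stronger inhibitor, a higher number a weaker inhibitor), compound 1 gives 569 nM, compound 2 gives 396 nM and compound 3 gives 272 nM. Compound 3 therefore stands within the scatter of compound 2 and beyond it from compound 1. The measured steps are a 2.1-fold lower number from compound 1 to compound 3 (0.32 log units; beyond the scatter), a 1.5-fold lower number from compound 2 to compound 3 (0.16 log units; within the scatter) and a 1.4-fold lower number from compound 1 to compound 2 (0.16 log units; within the scatter).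

Compound 4 `CCC(C)n1ncn(-c2ccc(N3CCN(c4ccc(OC[C@@H]5CO[C@@](Cn6cnc(C(F)(F)F)n6)(c6ccc(Cl)cc6Cl)O5)cc4)CC3)cc2)c1=O` takes the next step: trifluoromethyl in place of methyl on an aromatic carbon. This puts trifluoromethyl in place of methyl on an aromatic carbon of a five-membered aromatic ring with 3 nitrogen. Among the compounds with values here, no measured step changes this carbon. All three exchange the whole group on the chain carbon, so they bear on the new change only indirectly. The largest, a 2.1-fold lower number from compound 1 to compound 3 (0.32 log units; beyond the scatter), is modest, and no direction can be drawn from the data for methyl against trifluoromethyl. No shift beyond the scatter is therefore expected in this assay. The expected step is a 1.1-fold higher number from compound 3 to compound 4 (0.04 log units; within the scatter). For compound 4 the estimated value is 300 nM, with an expected range of 130 nM to 700 nM.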

Compound 4, half-maximal inhibitory concentration: 270 nM
Compound 4: middle estimate off by 1.1-fold (0.05 log units), on the high side; measured number inside the range.
By their numbers in this assay, from the lowest: compounds 4, 3, 2 and 1 (each within the scatter of the next, the first and the last beyond it).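

In this assay, within the data shown here, the change on this aromatic carbon of the five-membered aromatic ring with 3 nitrogen gives a 1.0-fold lower number from compound 3 to compound 4 (0.00 log units; within the scatter) and is the first measured change at this carbon, so here methyl and trifluoromethyl cannot be told apart. The other two new steps show that 3-(trifluoromethyl)-1H-1,2,4-triazol-1-yl on the chain carbon stands as 3-methyl-1H-1,2,4-triazol-1-yl does: a 1.5-fold lower number from compound 2 to compound 4 (0.17 log units; within the scatter) against 4-methylpiperazin-1-yl, and a 2.1-fold lower number from compound 1 to compound 4 (0.32 log units; beyond the scatter) against bromo, which repeats the modest separation from bromo already seen with the methyl group. Nothing available explains why this exchange leaves the number in place.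

Going by these compounds, only methyl and trifluoromethyl have been seen on this carbon, so it remains open whether a group of another kind there, such as an amine, a carboxylic acid or a longer chain, would also stay within the scatter. On these data alone, it also remains open whether the same exchange would read the same way in an assay other than this assay or with another group in place of the sec-butyl chain of the shared core.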